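Removing the isopropoxy group from compound 2

This account rests on a few compounds, and the source may have more. Where it says the series, first, only, none or still open, it means among the compounds named here.

Measured in a functional assay on MV4-11 cells (Homo sapiens) for antiproliferative activity, read by CCK-8 assay, with a stated time of 72 h (a higher number here means a weaker inhibitor, a lower number a stronger inhibitor), are two compounds:
- Compound 1 `Cn1cc(-c2cccc(C(C)(C)O)c2)c2cc(C(=O)NCc3ccc(C(=O)Nc4ccccc4N)cc3)[nH]c2c1=O` gives 2200 nM here
- Compound 2 `CC(C)Oc1ccccc1-c1cn(C)c(=O)c2[nH]c(C(=O)NCc3ccc(C(=O)Nc4ccccc4N)cc3)cc12` gives 130 nM here

Compound 2 holds the lower of the two numbers. Compound 3 `Cn1cc(-c2ccccc2)c2cc(C(=O)NCc3ccc(C(=O)Nc4ccccc4N)cc3)[nH]c2c1=O` has hydrogen in place of isopropoxy on an aromatic carbon, which leaves a plain phenyl. Going by the values given here, only one measured step bears on this, and it is large: a 17-fold lower number from compound 1 to compound 2 (1.23 log units; beyond the scatter) with 2-isopropoxyphenyl in place of 3-(1-hydroxy-1-methylethyl)phenyl. Compound 3 carries neither group, so a rise of moderate size is expected, an estimated 3.1-fold higher number from compound 2 to compound 3 (0.49 log units; beyond the scatter) in this assay, smaller than that measured step. Compound 3 is estimated at 400 nM, with a range from 130 nM to 1300 nM.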

Compound 3, half-maximal inhibitory concentration: 230 nM
For compound 3 the middle estimate is 1.7-fold (0.24 log units) above the measured one; the measured number falls inside the stated range.
By their numbers in this assay, from the lowest: compounds 2 and 3 (each within the scatter of the next); then compound 1.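

In this assay, the isopropoxy group proves dispensable at this position, since its loss stays within the scatter (a 1.8-fold higher number from compound 2 to compound 3 (0.25 log units; within the scatter)) and the plain phenyl serves about as well. The large gap seen earlier therefore tracks the 1-hydroxy-1-methylethyl group, whose replacement by hydrogen gives a clear gain (a 9.6-fold lower number from compound 1 to compound 3 (0.98 log units; beyond the scatter)). No evidence accounts for either step. Still open, on these data alone, is how an amine or a methoxy group would read at the place isopropoxy held, and whether a carboxylic acid on the phenyl would bring the same penalty as 1-hydroxy-1-methylethyl.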